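Two amines on a thiocarbonyl carbon and what follows

A few compounds are considered here, and "the series" means these few. Any claim that something is new, unique, unknown or untested is made for them only; others in the source may bear on it.

Compound 2 `CC1CCN(C(=S)SCc2ccc(C(=O)Nc3ccccc3N)cc2)CC1` stands highest of the two compounds measured in a functional assay on HeLa cells (Homo sapiens) for antiproliferative activity, read by CCK-8 assay, with a stated time of 72 h, tested at 8 uM (a lower number here means a weaker effect, a higher number a stronger effect of the compound at the concentration tested), where compound 2 gives 72.5%. Within the data shown here, its nearest neighbour, compound 1 `Nc1ccccc1NC(=O)c1ccc(CSC(=S)N2CCCc3ccccc32)cc1`, gives 35.7% in this assay, and the single known step, a number 36.8 percentage points higher from compound 1 to compound 2 (beyond the scatter), shows that the group on the thiocarbonyl carbon can shift the read-out strongly. Compound 3 `CN(Cc1cccnc1)C(=S)SCc1ccc(C(=O)Nc2ccccc2N)cc1` is not yet measured; it differs from compound 2 only at that same position: methyl((pyridin-3-yl)methyl)amino in place of 4-methylpiperidin-1-yl on a thiocarbonyl carbon. The step from compound 1 to compound 2 is the only one that bears on this change, and it involved different groups, so it sets no direction, only a scale. Compound 3 is therefore expected to sit somewhat below compound 2, with a step of about a number 17.5 percentage points lower from compound 2 to compound 3 (beyond the scatter) in this assay, and its read-out is estimated at 55%, within the range 30% to 80%.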

Compound 3, a percentage reported as inhibition, at one concentration (the size of the read-out at that concentration, not a potency): 68.7%
Compound 3: middle estimate off by 13.7 percentage points, on the low side; the range from low to high includes it.
By their numbers in this assay, from the lowest: compound 1; then compounds 3 and 2 (each within the scatter of the next).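

In this assay, the change from the six-membered non-aromatic ring to a group carrying a six-membered aromatic ring and a hydrogen-bond acceptor gives a number 3.8 percentage points lower from compound 2 to compound 3 (within the scatter), so at this concentration the thiocarbonyl carbon accepts these two quite different amines without a read-out that can be told apart. The second comparison gives a number 33 percentage points higher from compound 1 to compound 3 (beyond the scatter), which shows that the large step seen earlier is not tied to 4-methylpiperidin-1-yl alone, since a second amine also stands clearly apart from 1,2,3,4-tetrahydroquinolin-1-yl. Nothing available explains why these amines differ from that group. On these data alone, whether a morpholin-4-yl or a dimethylamino group on the thiocarbonyl carbon would give a read-out like that of compound 2 or that of compound 1 stays open. A single concentration also leaves open how compound 2 and compound 3 compare in potency.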